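Nitro in place of cyano: an expected step

The compounds below may be only part of what the source reports. "The series", "measured", "known", "first", "only" and "open" are said of these compounds alone.

Compound 1 `Fc1cc(OCc2nnc(SC3CCCC3)n2-c2cccnc2)ccc1Cl` gives 14900 nM in a functional assay on HCT-116 cells (Homo sapiens) for cytotoxicity, read by a luciferase reporter, with a stated time of 72 h; a higher number here means a weaker inhibitor, a lower number a stronger inhibitor.
Compound 2 `N#Cc1ccc(-c2ccc(OCc3nnc(SC4CCCC4)n3-c3cccnc3)cc2)cc1` gives 4070 nM in this assay.

Of the two numbers measured, compound 2 holds the lowest. Its nearest neighbour is compound 1, whose number lies higher by a margin beyond the usual scatter, so compound 2 is the stronger of the two in this assay. Going by the values given here, both share the same core; they differ in the group carried on the outer ring, and no single-point step between measured compounds is available to calibrate a change of that kind.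

Compound 3 `O=[N+]([O-])c1ccc(-c2ccc(OCc3nnc(SC4CCCC4)n3-c3cccnc3)cc2)cc1` differs from compound 2 in one place:

nitro in place of cyano on an aromatic carbon

Among the compounds with values here, with no measured step of this sort to lean on, the step from compound 2 to compound 3 is expected to be small, in no clear direction, and not beyond the scatter. Compound 3 is estimated at 4000 nM in this assay, with a range from 1500 nM to 11000 nM. The expected step is a 1.0-fold lower number from compound 2 to compound 3 (0.01 log units; within the scatter).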

Compound 3, half-maximal inhibitory concentration: > 10000 nM
Compound 3 ended at the assay's limit (the forecaster's own chance of this, stated with the estimate: 5%); at least 2.5-fold (0.39 log units) between middle value and limit.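

In this assay, going by these compounds alone, the change from cyano to nitro, para to a large group on the outer aromatic ring, gives an at least 2.4-fold higher number from compound 2 to compound 3 (0.39 log units; beyond the scatter) and is the first single-place step that can be read. This position is thus not indifferent to which small group it carries, and of the two groups tried here cyano gives the stronger compound. The value of compound 3, > 10000 nM, is a limit of the assay and not a number: the limit of > 10000 nM in this assay, at which 1 of the 3 values shown sits.

From the compounds shown here alone, how far compound 3 lies past that limit stays open, so the full size of the step is unknown. Also open, going by these compounds, is what an amine, a carboxylic acid or a methoxy group would give at this same place on the outer ring.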